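The compounds below may be only part of what the source reports. "The series", "measured", "known", "first", "only" and "open" are said of these compounds alone.

In an ADME assay on HUVEC cells (Homo sapiens) for cytotoxicity, read by MTT assay, with a stated time of 24 h (on this read-out higher numbers stand for weaker inhibition and lower numbers for stronger inhibition), compound 1 (`C=C1CC[C@H]2C(C)(C)CCC[C@]2(C)[C@H]1CCC(C)CC(=O)O`) gives > 200000 nM as a limit of the assay. Compound 2 (`COc1ccc(/C=C2\CC[C@H]3C(C)(C)CCC[C@]3(C)[C@H]2CCC(C)CC(=O)O)cc1`) gives > 200000 nM as a limit too. Compound 3 (`Cc1ccc(/C=C2\CC[C@H]3C(C)(C)CCC[C@]3(C)[C@H]2CCC(C)CC(=O)O)cc1`) gives > 200000 nM as a limit as well, with no number of its own. For the measured compounds named here, the series so far sits at the limit of > 200000 nM in this assay, at which 3 of the 3 values shown sit, throughout. Compound 4 (`COc1ccc(/C=C2\CC[C@H]3C(C)(C)CCC[C@]3(C)[C@H]2CCC(C)CC(=O)O)cc1OC`) carries 3,4-dimethoxyphenyl in place of 4-methylphenyl on a double-bonded chain carbon bound to a double-bonded ring carbon in 3,4-dimethoxyphenyl in place of 4-methylphenyl. Going by the values given here, the one measured step that the two limits leave unreadable from compound 2 to compound 3 has no readable size, so no step beyond the scatter and no direction are expected in this assay for this change. The expected outcome is a step that the limit leaves unreadable from compound 3 to compound 4 as an estimate only. Compound 4 is expected at 250000 nM with an estimated range from 100000 nM to 600000 nM and will most likely be reported as a limit again.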

Compound 4, half-maximal inhibitory concentration: > 200000 nM
Compound 4 gave a limit, no number (the forecaster's own chance of this, stated with the estimate: 85%); the middle value is on the limit's open side.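

For the compounds shown here, compound 4 gives > 200000 nM in this assay, again a limit, so no step among compound 2, compound 3 and compound 4 can be read. Whether the aromatic groups in these compounds differ at all stays open, with every compound shown resting at one value: the limit of > 200000 nM in this assay, at which 4 of the 4 values shown sit.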